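This account rests on a few compounds, and the source may have more. Where it says the series, first, only, none or still open, it means among the compounds named here.

Compound 1 `CC(C)N(Cc1cccc(OCCCCCC(=O)O)c1)C(=O)c1ccc(-c2ccco2)cc1`: > 26000 nM, a limit of the assay.
Compound 2 `COc1cccc(-c2ccc(C(=O)N(Cc3cccc(OCCCCCC(=O)O)c3)C(C)C)cc2)c1`: > 20900 nM, a limit of the assay.
Compound 3 `Cc1nnc(-c2cccc(-c3ccc(C(=O)N(Cc4cccc(OCCCCCC(=O)O)c4)C(C)C)cc3)c2)o1`: > 26000 nM, a limit of the assay.

All three compounds were examined in an ADME assay on HEK293 cells (Homo sapiens) for cytotoxicity, read by CellTiter-Glo and resazurin assay, with a stated time of 72 h; on this read-out lower numbers stand for an effect already at smaller amounts and higher numbers for an effect only at larger amounts of compound. Compound 1 stands only at a limit, > 26000 nM, which is not a measured number. The same holds for its two companions: the limit of > 26000 nM in this assay, at which 2 of the 3 values shown sit, and (the limit of > 20900 nM in this assay, at which 1 of the 3 values shown sits). Because every value is a limit, the three steps between them cannot be read: a step that the two limits leave unreadable from compound 1 to compound 2, a step that the two limits leave unreadable from compound 1 to compound 3 and a step that the two limits leave unreadable from compound 2 to compound 3.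

Compound 4 `CCOC(=O)CCCCCOc1cccc(CN(C(=O)c2ccc(-c3ccco3)cc2)C(C)C)c1` is the compound not yet measured. It differs from compound 1 by ethyl in place of hydrogen on an oxygen next to a carbonyl group. Among the measured compounds shown here, none of the measured steps touches this end of the molecule; they all change the group on the far aromatic carbon, and all of them are unreadable anyway. For the measured compounds named here, there is thus no measured step that bears on this change, and nothing in the data points to an effect in this assay in either direction. The step from compound 1 to compound 4 is expected to be a number no higher from compound 1 to compound 4 (the limit leaves the size open), that is, no readable change. Compound 4 is expected to give 26000 nM in this assay, within 15000 nM to 50000 nM, most likely again only as a limit.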

Compound 4, half-maximal effective concentration: > 26000 nM
Compound 4 ended at the assay's limit; the forecaster's own chance of this, stated with the estimate: 85%; the middle value lies on the limit itself.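

In this assay compound 4 gives > 26000 nM, a limit of the assay and not a number. Compound 1 gives > 26000 nM, also a limit, so the change between compound 1 and compound 4 cannot be read. The compounds shown leave open at what amount, if any, these four compounds would show an effect in this assay.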